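This account rests on a few compounds, and the source may have more. Where it says the series, first, only, none or still open, it means among the compounds named here.

Measured in an ADME assay on HEK293 cells (Homo sapiens) for cytotoxicity, read by MTT assay, with a stated time of 48 h; a lower number here means a stronger inhibitor, a higher number a weaker inhibitor:
compound 1 `CN(c1ccc(NC(=O)c2cc(C(F)(F)F)cc(C(F)(F)F)c2)cc1OCc1cccc(C(F)(F)F)c1)S(C)(=O)=O`: > 500000 nM
compound 2 `CCCCCCOc1cc(NC(=O)c2cc(C(F)(F)F)cc(C(F)(F)F)c2)ccc1N(C)S(C)(=O)=O`: > 500000 nM

Both entries are limits of this assay, not numbers. For compound 1 the value > 500000 nM is such a limit. For compound 2 the value > 500000 nM is likewise a limit. Compound 1 therefore stands only at the edge of what this assay reports, at the limit of > 500000 nM in this assay, at which 2 of the 2 values shown sit. Within the data shown here, the single measured step, a step that the two limits leave unreadable from compound 1 to compound 2, cannot be read, both ends being limits.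

Compound 3 `CN(c1ccc(NC(=O)c2cc(C(F)(F)F)cc(C(F)(F)F)c2)cc1OCc1cccc(C(F)(F)F)c1)S(=O)(=O)Cc1ccccc1` differs from compound 1 by phenyl in place of hydrogen on a saturated chain carbon bound to a sulfonyl sulfur. Among the measured compounds shown here, no measured step touches this part of the molecule, and the one step that exists is unreadable, so no direction or size can be drawn from the measured pairs. The working expectation is that compound 3 again sits at the limit, with an estimate of 500000 nM and a range from 150000 nM to 1500000 nM. The step from compound 1 to compound 3 is thus expected to be a number no higher from compound 1 to compound 3 (the limit leaves the size open), not beyond the scatter.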

Compound 3, half-maximal inhibitory concentration: 59800 nM
The estimate for compound 3 lay 8.4-fold (0.92 log units) above the measured number; the measured number lies below the stated range.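

In this assay, the change from methylsulfonyl to benzylsulfonyl gives an at least 8.3-fold lower number from compound 1 to compound 3 (0.92 log units; beyond the scatter), so a change on the saturated chain carbon bound to the sulfonyl sulfur can bring the read-out within the measurable range. The earlier pair could not show this: its step, on the other side of the molecule, cannot be read, and compound 1 and compound 2 each stand only at a limit of the assay: the limit of > 500000 nM in this assay, at which 2 of the 3 values shown sit. Among these compounds, with compound 1 at a limit, the new step gives only a minimum size, and the single pair establishes no trend.

Still open, as far as these compounds go, is whether the phenyl ring is needed, or whether a longer chain such as butyl on the same carbon would also lower the number. Also open, from the compounds shown here alone, is how a benzyl ring carrying an amine or a carboxylic acid would read.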